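The source may report more compounds than this note shows. Statements on the series, on what has been measured and on what is new or still open speak of the compounds shown alone.

Compound 1 `O=C(O)Cc1sc(Nc2ccccc2)nc1-c1ccc(F)cc1` gives > 70% in an in vitro functional assay on HEK285-7 cells for antagonist activity at prostaglandin D2 receptor 2 (Homo sapiens), read by BRET and beta-arrestin recruitment; on this read-out lower numbers stand for smaller maximal responses and higher numbers for larger maximal responses.
Compound 2 `O=C(O)Cc1sc(Nc2ccc(Cl)cc2)nc1-c1ccc(F)cc1` gives > 70% in this assay.
Compound 3 `O=C(O)Cc1sc(Cc2ccc(Cl)cc2)nc1-c1ccccc1` gives > 70% in this assay.

The value of compound 1 is a limit of the assay, not a number. The value of compound 2 is likewise a limit. The value of compound 3 is also a limit. The change from compound 1 to compound 2 is chloro in place of hydrogen on an aromatic carbon, and its step, a step that the two limits leave unreadable from compound 1 to compound 2, cannot be read because of the limit of > 70% in this assay, at which 3 of the 3 values shown sit. The difference between the cores of compound 1 and compound 3 is not broken down here. Compound 4 `O=C(O)Cc1sc(Cc2ccc(Cl)cc2)nc1-c1ccc(Cl)cc1` has not yet been measured; it differs from compound 3 by chloro in place of hydrogen on an aromatic carbon, the same change as from compound 1 to compound 2. Since all three measured values sit at the limit, compound 4 is expected to reach the limit as well, a step that the limit leaves unreadable from compound 3 to compound 4. The estimate for compound 4 in this assay is 85%.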

Compound 4, largest response reached (reported as efficacy), in percent of the reference or control that the assay uses: > 70%
Compound 4: no number, only a limit; the forecaster's own chance of this, stated with the estimate: 85%; the middle value does not contradict the limit.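

The step between compound 3 and compound 4 cannot be read, since both values are limits, not numbers: the limit of > 70% in this assay, at which 4 of the 4 values shown sit.

The compounds shown leave open how large each maximal response really is, and whether chloro in place of hydrogen changes it at all in this assay.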